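Methoxy for methyl on the aryl ring of compound 3

A few compounds are considered here, and "the series" means these few. Any claim that something is new, unique, unknown or untested is made for them only; others in the source may bear on it.

Three compounds of the series carry the same guanidine-linked core and a branched aryl-pyridyl arm. Compound 1 `N=C(NCCCc1c[nH]cn1)NCCSC(c1ccccc1)c1ccccn1` gives 1 in a functional assay on cardiac atrium for agonist activity at histamine H2 receptor (Cavia porcellus); on this read-out higher numbers stand for larger maximal responses and lower numbers for smaller maximal responses. Compound 2 `N=C(NCCCc1c[nH]cn1)NCCC(c1ccccc1)c1ccccn1` gives 1 in this assay. Compound 3 `Cc1ccc(C(CC/N=C(\N)NCCCc2c[nH]cn2)c2ccccn2)cc1` gives 1 in this assay. On these numbers compound 3 stands level with compound 1 and compound 2 at the digits shown; the gaps to both lie within the usual scatter, so no order among the three can be read from them. All three reach the full response of the reference agonist.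

Compound 4 `COc1ccc(C(CC/N=C(\N)NCCCc2c[nH]cn2)c2ccccn2)cc1` is the next member. It differs from compound 3 in one place: methoxy in place of methyl on an aromatic carbon. The remainder of the molecule is unchanged. For the measured compounds named here, no measured pair in the set carries this same change, so the size of the step rests on the picture above, where the whole arm has been varied without the maximal response moving off the ceiling.

The step from compound 3 to compound 4 in this assay is therefore expected to be about no change at the digits printed from compound 3 to compound 4 (within the scatter), within the scatter. For compound 4 the intrinsic activity in this assay is estimated at 1, with a range of 0.85 to 1.05.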

Compound 4, intrinsic activity: the largest response reached, as a fraction of the reference agonist's: 1
The estimate for compound 4 equals the measured number at the digits printed; measured number inside the range.
By their numbers in this assay, from the lowest: compounds 1, 2, 3 and 4 (each within the scatter of the next).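

In this assay, putting methoxy in place of methyl on the aromatic carbon para to a large group gives no change at the digits printed from compound 3 to compound 4 (within the scatter). Compound 4 is the first compound shown with an oxygen at this place on the ring, and it adds a hydrogen-bond acceptor and a second heavy atom to the group, so the maximal response stays level with compound 3 across this change of size and acceptor count. Nothing at hand bears on what lies behind this outcome.

From the compounds shown here alone, whether an amine, a carboxylic acid or a longer chain such as ethoxy at this position would bring the maximal response down remains open. With all four compounds level, this read-out also leaves open whether the 4-methylphenyl to 4-methoxyphenyl change would matter on any measure other than maximal response.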